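A few compounds are considered here, and "the series" means these few. Any claim that something is new, unique, unknown or untested is made for them only; others in the source may bear on it.

Among the compounds with values here, in a functional assay on BGC-823 cells (Homo sapiens) for antiproliferative activity, read by MTT assay (on this read-out higher numbers stand for weaker inhibition and lower numbers for stronger inhibition), compound 2 `Cc1cccc(NC(=O)/C(C#N)=C/c2cc(O)c(O)c([N+](=O)[O-])c2)c1` gives 5.6 ug/mL, the only plain number among the values shown. Compound 1 `N#C/C(=C\c1cc(O)c(O)c([N+](=O)[O-])c1)C(=O)N(c1ccccc1)c1ccccc1` gives > 100 ug/mL, which is a limit of the assay rather than a number, as the limit of > 100 ug/mL in this assay, at which 1 of the 2 values shown sits, records. Compound 3 `COc1ccc(NC(=O)/C(C#N)=C/c2cc(O)c(O)c([N+](=O)[O-])c2)cc1` has not yet been measured; it carries 4-methoxyphenyl in place of 3-methylphenyl on an amide-type nitrogen, that is, 4-methoxyphenyl in place of 3-methylphenyl on an amide-type nitrogen. Within the data shown here, no measured pair shows such a change, so only a small shift, or none beyond the usual scatter, is expected. That move is expected to amount to a 1.4-fold higher number from compound 2 to compound 3 (0.15 log units; within the scatter) in this assay. Compound 3 is therefore estimated at 8 ug/mL, within a likely range of 3 ug/mL to 25 ug/mL.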

Compound 3, half-maximal inhibitory concentration: 45.4 ug/mL
For compound 3 the middle estimate is 5.7-fold (0.75 log units) below the measured one, outside the stated range (above it).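

In this assay, replacing 3-methylphenyl with 4-methoxyphenyl on the amide-type nitrogen gives an 8.1-fold higher number from compound 2 to compound 3 (0.91 log units; beyond the scatter). Within the data shown here, this is the only readable step at this position, and it shows that the choice of ring group on this nitrogen can matter, with compound 2 the stronger inhibitor of the pair. Nothing shown here explains the size of this step. From the compounds shown here alone, the change swaps methyl for methoxy and also alters the ring position, so which of the two matters remains open. Going by these compounds, how an amine or a carboxylic acid on this ring would read also remains open.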